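Chloro gain on the 4-chlorophenyl series: working notes

This account rests on a few compounds, and the source may have more. Where it says the series, first, only, none or still open, it means among the compounds named here.

- Compound 1 `NC1=NC2(CCSCC2)N(OCCCOc2ccc(Cl)c(Cl)c2)C(N)=N1` gives 70 nM
- Compound 2 `NC1=NC2(CCSCC2)N(OCCCOc2cccc(Cl)c2)C(N)=N1` gives 90 nM
- Compound 3 `NC1=NC2(CCOCC2)N(OCCCOc2ccc(Cl)cc2)C(N)=N1` gives "not determined" (no result reported)

These entries all come from a functional assay on HepG2 cells (Homo sapiens) for antiproliferative activity, read by MTT assay, with a stated time of 72 h (on this read-out lower numbers stand for stronger inhibition and higher numbers for weaker inhibition), and they leave the next step without a starting number. Compound 3 stands at "not determined" (no result reported) on this read-out, so it offers no value to build on.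

The step leads to compound 4 `NC1=NC2(CCOCC2)N(OCCCOc2ccc(Cl)c(Cl)c2)C(N)=N1` with the change chloro in place of hydrogen on an aromatic carbon in which chloro takes the place of hydrogen on an aromatic carbon, turning 4-chlorophenyl into 3,4-dichlorophenyl. The nearest measured evidence is a single step on a different core, a 1.3-fold higher number from compound 1 to compound 2 (0.11 log units; within the scatter) for the reverse kind of exchange, hydrogen in place of chloro on an aromatic carbon. The chloro lost there is not the one gained here, so the parallel is only partial. Read in reverse, that step gives no reason to expect a change beyond the scatter from adding a chloro.

The estimate therefore leans on compound 1 at 70 nM as the compound carrying the same 3,4-dichlorophenyl group. Among the measured compounds shown here, no measured pair shows what the difference in core does, so the range stays wide.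

In this assay compound 4 is estimated at 100 nM with an expected range from 30 nM to 350 nM as the working figure.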

Compound 4, half-maximal inhibitory concentration: 380 nM
The estimate for compound 4 lay 3.8-fold (0.58 log units) below the measured number; the measured number lies above the stated range.
By their numbers in this assay, from the lowest: compounds 1 and 2 (each within the scatter of the next); then compound 4.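

Among the compounds shown here, with compound 3 offering no number in this assay, no step from compound 3 to compound 4 can be read. No evidence on hand bears on this result.

The compounds shown leave open whether gaining the chloro on 4-chlorophenyl moves the number on this core, and what the core itself contributes to the 380 nM of compound 4.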